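The compounds below may be only part of what the source reports. "The series", "measured", "known", "first", "only" and "open" are said of these compounds alone.

Going by the values given here, in a functional assay on A549 cells (Homo sapiens) for antiproliferative activity, read by MTT assay, with a stated time of 72 h (a higher number here means a weaker inhibitor, a lower number a stronger inhibitor), compound 1 `COc1cc(CCc2ccccc2)cc(OC)c1O` gives 10900 nM as the lower of the two numbers so far, and compound 2 `COc1cc(CCc2ccc(Cl)cc2)cc(OC)c1O` gives 22900 nM in the same test. Compound 3 `COc1ccccc1CCc1cc(OC)c(O)c(OC)c1` differs from compound 1 through methoxy in place of hydrogen on an aromatic carbon and thus has methoxy in place of hydrogen on an aromatic carbon, ortho to a large group. The one measured substitution, a 2.1-fold higher number from compound 1 to compound 2 (0.32 log units; beyond the scatter) for chloro in place of hydrogen, bears only indirectly, since it involves a different group. A small move to a higher number is therefore expected, with a 1.3-fold higher number from compound 1 to compound 3 (0.11 log units; within the scatter) as the estimated step in this assay for now. Compound 3 is estimated at 14000 nM with a range of 6000 nM to 32000 nM as the expected span.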

Compound 3, half-maximal inhibitory concentration: 1740 nM
Estimate against measurement, compound 3: 8.0-fold (0.91 log units) above, outside the stated range (below it).
By their numbers in this assay, from the lowest: compound 3; then compound 1; then compound 2.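

Adding a methoxy group ortho to a large group gives a 6.3-fold lower number from compound 1 to compound 3 (0.80 log units; beyond the scatter) in this assay and so runs opposite to chloro, which gave a 2.1-fold higher number from compound 1 to compound 2 (0.32 log units; beyond the scatter) for the only earlier change. Substitution on this six-membered aromatic ring of carbon only can therefore move the number either way, although the two changes differ in group as well as in place. No measurement here bears on the reason for the lower number of compound 3.

Going by these compounds, it remains open whether a smaller hydroxy group or an amine in this same place would keep the lower number. On these data alone, the effect of methoxy elsewhere on this ring also remains open.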